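The compounds below may be only part of what the source reports. "The series", "measured", "known", "first", "only" and "open" are said of these compounds alone.

Measured so far in an assay on HEK cells for antagonist activity at transient receptor potential cation channel subfamily V member 1 (Homo sapiens), read by FLIPR; on this read-out higher numbers stand for weaker inhibition and lower numbers for stronger inhibition:
compound 1 `O=C(NCc1ccc(C(F)(F)F)nc1N1CCCC1)Nc1cccc2[nH]c(=O)ccc12`: 0.94 nM
compound 2 `CCCCCOc1nc(C(F)(F)F)ccc1CNC(=O)Nc1cccc2[nH]c(=O)ccc12`: 2.72 nM

Among the compounds with values here, compound 2 carries the highest of the two numbers in this assay; its only neighbour is compound 1, and the single measured step is a 2.9-fold higher number from compound 1 to compound 2 (0.46 log units; beyond the scatter), a modest step that came with pentyloxy in place of pyrrolidin-1-yl on an aromatic carbon.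

Compound 3 `O=C(NCc1ccc(C(F)(F)F)nc1OCC1CCC1)Nc1cccc2[nH]c(=O)ccc12` differs from compound 2 by cyclobutyl in place of butyl on a saturated chain carbon bound to an oxygen on an aromatic ring. Within the data shown here, no measured step bears directly on this change: the step from compound 1 to compound 2 swaps the whole group on the aromatic carbon, whereas here the oxygen and the first chain carbon stay and only the outer part of the chain is closed into a ring, with the same count of heavy atoms on each side. There is thus no basis in the numbers for a step beyond the scatter in either direction. The working expectation is a step of a 1.1-fold lower number from compound 2 to compound 3 (0.04 log units; within the scatter) in this assay, that is, essentially no change. Compound 3 is accordingly estimated at 2.5 nM in this assay, with a range from 1 nM to 6.5 nM.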

Compound 3, half-maximal inhibitory concentration: 1.49 nM
For compound 3 the middle estimate is 1.7-fold (0.22 log units) above the measured one, and the stated range covers the measured number.
By their numbers in this assay, from the lowest: compounds 1, 3 and 2 (each within the scatter of the next, the first and the last beyond it).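

In this assay, closing the outer part of the pentyloxy chain into a ring, with butyl and cyclobutyl of equal heavy-atom count, gives a 1.8-fold lower number from compound 2 to compound 3 (0.26 log units; within the scatter); the chain carbon bound to the oxygen on the aromatic ring therefore accepts cyclobutyl in place of butyl without a step that can be told from the scatter. Within the data shown here, the other new comparison gives a 1.6-fold higher number from compound 1 to compound 3 (0.20 log units; within the scatter), so an oxygen-linked group at this aromatic carbon is not in itself set apart from pyrrolidin-1-yl: cyclobutylmethoxy stays within the scatter of pyrrolidin-1-yl, whereas pentyloxy, the one group that goes against this, lies beyond it. No measurement shown here explains either step.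

The compounds shown leave open how far the ring on the oxygen-linked chain can vary, since cyclopropylmethoxy and cyclohexylmethoxy would test whether the numbers stay this close on either side of cyclobutylmethoxy. Also open, going by these compounds, is whether an open-chain amine such as diethylamino, or a larger ring amine such as piperidin-1-yl, would stand with pyrrolidin-1-yl at this aromatic carbon.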